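Swapping the Aryl Sulfone Substituent in a Quinoline Series

The source may report more compounds than this note shows. Statements on the series, on what has been measured and on what is new or still open speak of the compounds shown alone.

Measured compounds:
Compound 1 `Cc1cc(C)cc(S(=O)(=O)c2cnc3cc(F)ccc3c2N2CCC(C)CC2)c1`: 80%
Compound 2 `CC1CCN(c2c(S(=O)(=O)c3ccc(C#N)cc3)cnc3ccc(Cl)cc23)CC1`: 31%

In an assay on isolated protein for displacement of a labelled ligand from metabotropic glutamate receptor 5 (Homo sapiens), with a stated time of 60 min, tested at 1 uM (a lower number here means less inhibition, a higher number more inhibition at the concentration tested (going by the name of the read-out)), compound 1 gives 80%, the higher of the two numbers recorded, and in this assay compound 2 gives 31%, a gap that lies beyond the usual scatter. No single-point change between compound 1 and compound 2 has been measured, so only their two values can be compared. Compound 3 `Cc1ccc(S(=O)(=O)c2cnc3cc(F)ccc3c2N2CCC(C)CC2)cc1` has not yet been measured in this assay. It differs from compound 1 in one place: 4-methylphenyl in place of 3,5-dimethylphenyl on a sulfonyl sulfur. Among the measured compounds shown here, with no measured step of this kind to draw on, a modest downward change from compound 1 is expected, of the order of a number 15 percentage points lower from compound 1 to compound 3 (beyond the scatter), though a result within the scatter would not surprise. For compound 3 the expected inhibition in this assay is estimated at 65%, with a plausible range from 40% to 85%.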

Compound 3, a percentage reported as inhibition, at one concentration (the size of the read-out at that concentration, not a potency): 88%
The estimate for compound 3 lay 23 percentage points below the measured number; the measured number lies above the stated range.
By their numbers in this assay, from the lowest: compound 2; then compounds 1 and 3 (each within the scatter of the next).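

In this assay, among the compounds shown here, 4-methylphenyl in place of 3,5-dimethylphenyl on a sulfonyl sulfur gives a number 8 percentage points higher from compound 1 to compound 3 (within the scatter), the first measured single-place step. At this position, then, the two aryl groups cannot be told apart in this read-out, and the second methyl of 3,5-dimethylphenyl is not needed to retain the inhibition seen with compound 1. No measurement available here accounts for this result.

Compound 2 differs from compound 1 and compound 3 in more than one place, so its value cannot be assigned to its aryl sulfone substituent alone. On these data alone, whether this position would accept an unsubstituted phenyl, or a phenyl carrying an amine or a carboxylic acid, on the core of compound 3 remains open.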